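From thiophen-3-yl to thiophen-2-yl on the shared core

The source may hold more compounds than are shown below. What is called first, only, known or untested is meant among the compounds shown, and "the series" means these compounds.

compound 1 `COc1cc(C(=O)c2sc(-c3ccc([N+](=O)[O-])cc3)cc2N)cc(OC)c1OC`: 64 nM
compound 2 `COc1cc(C(=O)c2sc(-c3cccc([N+](=O)[O-])c3)cc2N)cc(OC)c1OC`: 17 nM
compound 3 `COc1cc(C(=O)c2sc(-c3ccsc3)cc2N)cc(OC)c1OC`: 3.7 nM

In a functional assay on FM3A cells (Mus musculus) for antiproliferative activity (a lower number here means a stronger inhibitor, a higher number a weaker inhibitor), compound 3 gives 3.7 nM and holds the lowest of the three numbers, clear of both compound 2 and compound 1. Compound 4 `COc1cc(C(=O)c2sc(-c3cccs3)cc2N)cc(OC)c1OC` has not yet been measured. It differs from compound 3 by one change: thiophen-2-yl in place of thiophen-3-yl on an aromatic carbon, on the aromatic carbon next to the ring sulfur, with the same atoms joined differently.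

Going by the values given here, no measured pair compares the two thiophene attachments directly. Among the compounds with values here, the nearest precedent is a 3.8-fold lower number from compound 1 to compound 2 (0.58 log units; beyond the scatter), a modest step in which the nitrophenyl group keeps its atoms and only the attachment of the nitro group differs. The replacements of a nitrophenyl group are wider changes: a 4.6-fold lower number from compound 2 to compound 3 (0.66 log units; beyond the scatter) is modest and a 17-fold lower number from compound 1 to compound 3 (1.24 log units; beyond the scatter) is large.

Within the data shown here, with compound 3 at 3.7 nM as the lowest number so far, a small to modest rise in this assay is expected rather than a further fall. The estimated step is a 2.2-fold higher number from compound 3 to compound 4 (0.33 log units; beyond the scatter) and a result within the scatter would fit as well. Compound 4 is estimated at 8 nM with an expected range from 2.5 nM to 26 nM in this assay.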

Compound 4, half-maximal inhibitory concentration: 1.7 nM
Compound 4: the middle estimate sits 4.7-fold (0.67 log units) above what was measured, and the stated range ends above it.
By their numbers in this assay, from the lowest: compound 4; then compound 3; then compound 2; then compound 1.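

In this assay the thiophene attachment alone gives a 2.2-fold lower number from compound 3 to compound 4 (0.34 log units; beyond the scatter) at this position, so the number responds to how the ring is joined even though thiophen-3-yl and thiophen-2-yl have the same atoms and the same counted donors and acceptors. Replacing the nitrophenyl groups with thiophen-2-yl gives a 10-fold lower number from compound 2 to compound 4 (1.00 log units; beyond the scatter) and a 38-fold lower number from compound 1 to compound 4 (1.58 log units; beyond the scatter) in the same series, and among these four compounds both thiophenes stand lower than both nitrophenyl groups, with none going against that order. Nothing measured here bears on the reason for the difference between the two thiophene attachments.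

The compounds shown leave open whether a furan-2-yl or an unsubstituted phenyl group in this place, or a thiophen-2-yl carrying a methyl group or a chlorine, would keep a number this low. They also leave open whether the order of the two thiophene attachments would hold if the amino group on the shared core were replaced by a hydroxyl group or a methylamino group.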